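Trifluoromethyl on the fused ring core: an expected step

This account rests on a few compounds, and the source may have more. Where it says the series, first, only, none or still open, it means among the compounds named here.

Measured so far:
compound 1 `CCCc1ccc(S(=O)(=O)NC(=O)OCCC(F)(F)C(F)(F)F)c(-c2ccc(Cn3c(C(C)(C)C)nc4ccccc43)cc2)c1`: 6 nM
compound 2 `CCCCOC(=O)NS(=O)(=O)c1ccc(CCC)cc1-c1ccc(Cn2cnc3ccccc32)cc1`: 29 nM

Of the compounds shown here, two have been measured in an assay on membranes from HEK293 cells for displacement of a labelled ligand from Type-2 angiotensin II receptor (Homo sapiens), read by radioligand binding; on this read-out lower numbers stand for stronger inhibition and higher numbers for weaker inhibition. Compound 1 `CCCc1ccc(S(=O)(=O)NC(=O)OCCC(F)(F)C(F)(F)F)c(-c2ccc(Cn3c(C(C)(C)C)nc4ccccc43)cc2)c1` gives 6 nM in this assay, and compound 2 `CCCCOC(=O)NS(=O)(=O)c1ccc(CCC)cc1-c1ccc(Cn2cnc3ccccc32)cc1` gives 29 nM. Compound 2 therefore stands at the weaker end of the two numbers, and its gap to compound 1 lies beyond the scatter of repeated measurements. Among the measured compounds shown here, compound 1 differs from compound 2 in more than one place, so only the two values themselves can be compared, and no single step between them is known.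

Compound 3 `CCCCOC(=O)NS(=O)(=O)c1ccc(CCC)cc1-c1ccc(Cn2c(C(F)(F)F)nc3ccccc32)cc1` has not yet been measured. It differs from compound 2 in one place: trifluoromethyl in place of hydrogen on an aromatic carbon. Because compound 2 gives 29 nM and nothing in the two measured compounds isolates this particular change, the direction of its effect is not settled by the data. Compound 3 is expected to give 15 nM in this assay, between 5 nM and 45 nM. This estimate amounts to a step of a 1.9-fold lower number from compound 2 to compound 3 (0.29 log units; within the scatter), a modest movement that may or may not exceed the scatter.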

Compound 3, inhibition constant: 13 nM
Compound 3: middle estimate off by 1.2-fold (0.06 log units), on the high side, and the stated range covers the measured number.
By their numbers in this assay, from the lowest: compound 1; then compound 3; then compound 2.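

In this assay, putting trifluoromethyl in place of hydrogen on this aromatic carbon gives a 2.2-fold lower number from compound 2 to compound 3 (0.35 log units; beyond the scatter), a modest change that still lies beyond the usual scatter. Among the compounds shown here, this is the first single change that can be read, since compound 1 and compound 2 differ in more than one place and their values could not be tied to any one group. It shows that this carbon, on a five-membered aromatic ring with 2 nitrogen and between two ring nitrogen atoms, can carry 4 more heavy atoms with a lower number rather than a higher one, even though it lies next to the ring atom that bears a large group; nothing measured here accounts for the change.

From the compounds shown here alone, one replacement at one carbon does not establish a trend, so it remains open whether a methyl group, a chlorine atom or an amine at the same place would also lower the number. Going by these compounds, it is equally open whether trifluoromethyl would give a step of similar size in a compound with a different chain on the carbamate oxygen, such as a shorter alkyl chain in place of the butyl chain of compound 3.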